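The source may report more compounds than this note shows. Statements on the series, on what has been measured and on what is new or still open speak of the compounds shown alone.

Of the compounds shown here, three have been measured in a functional assay on 1321-N1 cells for agonist activity at Free fatty acid receptor 1 (Homo sapiens), read by calcium flux, with a stated time of 0.4 s; a lower number here means that less compound is needed, a higher number that more compound is needed for the effect. Compound 1 `O=C(O)CCc1ccc(C#CC2CCCC2)cc1` gives 490 nM. Compound 2 `C/C=C\C#Cc1ccc(CCC(=O)O)c(F)c1`, which carries a prop-1-en-1-yl group on the triple-bonded carbon and a fluorine on the shared core, gives 47.9 nM. Compound 3 `C/C=C(\C)C#Cc1ccc(CCC(=O)O)c(F)c1` gives 37.2 nM, the lowest of the three numbers shown, although the step of a 1.3-fold lower number from compound 2 to compound 3 (0.11 log units; within the scatter) is within the scatter, so compounds 2 and 3 cannot be told apart on these data; compound 1 stands clearly apart with its higher number.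

Compound 4 `C/C(C#Cc1ccc(CCC(=O)O)c(F)c1)=C/CO` has not yet been measured. It differs from compound 3 in one place: 3-hydroxy-1-methylprop-1-en-1-yl in place of 1-methylprop-1-en-1-yl on a triple-bonded carbon. A hydroxyl thus enters the chain while the methyl stays. Among the measured compounds shown here, no measured step introduces a hydroxyl anywhere, so nothing directly tells how this assay responds to it. For the measured compounds named here, the only step that touches this chain, a 1.3-fold lower number from compound 2 to compound 3 (0.11 log units; within the scatter), added a methyl and stayed within the scatter, which bears on the present change only loosely. The expectation is therefore a small step, if any, leaning toward a somewhat higher number in this assay. For compound 4 the estimate is 60 nM, within the range 20 nM to 180 nM, which means an expected step of a 1.6-fold higher number from compound 3 to compound 4 (0.21 log units; within the scatter).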

Compound 4, half-maximal effective concentration: 427 nM
Compound 4: middle estimate off by 7.1-fold (0.85 log units), on the low side; measured number above the stated range.
By their numbers in this assay, from the lowest: compounds 3 and 2 (each within the scatter of the next); then compounds 4 and 1 (each within the scatter of the next).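

Among the compounds shown here, this position on a triple-bonded carbon is clearly not indifferent to what it carries: in this assay, placing 3-hydroxy-1-methylprop-1-en-1-yl where 1-methylprop-1-en-1-yl stood gives an 11-fold higher number from compound 3 to compound 4 (1.06 log units; beyond the scatter) and is the first step at this position to lie beyond the scatter. The same holds against the group without the methyl, since 3-hydroxy-1-methylprop-1-en-1-yl in place of prop-1-en-1-yl gives an 8.9-fold higher number from compound 2 to compound 4 (0.95 log units; beyond the scatter) in this assay, so the higher number appears with either of the two earlier compounds as the reference. Nothing measured on these compounds bears on this rise.

As far as these compounds go, it remains open whether the higher number belongs to the hydroxyl itself or would also follow from another group in its place, such as a methoxy, an amine or a carboxylic acid. From the compounds shown here alone, it is equally open whether a longer chain carrying the hydroxyl, or a hydroxyl-bearing chain without the methyl, would give a number closer to those of compound 2 and compound 3.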